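This account rests on a few compounds, and the source may have more. Where it says the series, first, only, none or still open, it means among the compounds named here.

Measured compounds:
Compound 1, `Cc1cccc(-n2nncc2CN2C(=O)C3(C(C#N)=C(N)Oc4c3c3nc5ccccc5nc3c3ccccc43)c3ccccc32)c1`, in a functional assay on MCF7 cells (Homo sapiens) for antiproliferative activity, read by MTT assay, with a stated time of 48 h (on this read-out lower numbers stand for stronger inhibition and higher numbers for weaker inhibition), gives > 50000 nM, which is a limit of the assay and not a number.
Compound 2, `CCc1ccccc1-n1nncc1CN1C(=O)C2(C(C#N)=C(N)Oc3c(N)cc4nc5ccccc5nc4c32)c2ccccc21`, in this assay gives 24600 nM.

Among the measured compounds shown here, compound 2 stands at the only numerical value found so far in this assay; the other measured result is a limit (the limit of > 50000 nM in this assay, at which 1 of the 2 values shown sits). Compound 3, `N#CC1=C(N)Oc2c(N)cc3nc4ccccc4nc3c2C12C(=O)N(Cc1cnnn1-c1cccc(C(F)(F)F)c1)c1ccccc12`, differs from compound 2 by 3-(trifluoromethyl)phenyl in place of 2-ethylphenyl on an aromatic nitrogen. For the measured compounds named here, no step between two measured compounds has been counted, so compound 2 is the only anchor, and the shared core of compound 2 and compound 3 is unchanged. In this assay the step is expected to be small, in no clear direction and not beyond the usual scatter, with a real chance that compound 3 is reported only as a limit. Compound 3 is expected to give 30000 nM, between 9000 nM and 100000 nM. This estimate means a step of a 1.2-fold higher number from compound 2 to compound 3 (0.09 log units; within the scatter).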

Compound 3, half-maximal inhibitory concentration: 31600 nM
Beside the measured number, compound 3's estimate is 1.1-fold (0.02 log units) below it; the measured number falls inside the stated range.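

On the aromatic nitrogen of the five-membered ring, 3-(trifluoromethyl)phenyl in place of 2-ethylphenyl gives a 1.3-fold higher number from compound 2 to compound 3 (0.11 log units; within the scatter) in this assay and so leaves the read-out within the scatter. Among the compounds shown here, this is the first readable step at this position, and it shows that these two substituted phenyl groups cannot be told apart here on the shared core. For the compounds shown here, compound 1 is a limit and not a number, and it adds no step: the limit of > 50000 nM in this assay, at which 1 of the 3 values shown sits.

The exchange alters both the substituent and its place on the phenyl ring, so the compounds shown do not separate these two changes. Also open, on these data alone, is how an amine or a carboxylic acid on that phenyl ring, or a longer alkyl chain in place of the ring, would read in this assay at this position.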